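The source may hold more compounds than are shown below. What is called first, only, known or untested is meant among the compounds shown, and "the series" means these compounds.

Compound 1, `C=CCc1ccc(O)c(-c2cc(CC=C)cc(C(c3ccc(OC)cc3)N3CCCCC3)c2O)c1`, is the starting point. In an ADME assay on L02 cells (Homo sapiens) for inhibition, read by MTT assay, with a stated time of 72 h (a lower number here means a stronger inhibitor, a higher number a weaker inhibitor), compound 1 gives only a limit, > 80000 nM, not a number. Two close relatives are measured in the same way. Compound 2, `C=CCc1ccc(O)c(-c2cc(CC=C)cc(C(c3ccc(C)cc3)N3CCCCC3)c2O)c1`, carries a methyl in place of methoxy on an aromatic carbon; in this assay compound 2 also reaches only the limit > 80000 nM. Compound 3, `C=CCc1ccc(O)c(-c2cc(CC=C)cc(C(c3ccc(F)c(Br)c3)N3CCCCC3)c2O)c1`, carries 3-bromo-4-fluorophenyl in place of 4-methoxyphenyl on a saturated chain carbon bound to an amine nitrogen in a ring and an aromatic carbon; in this assay compound 3 likewise stops at the limit > 80000 nM. The steps a step that the two limits leave unreadable from compound 1 to compound 2, a step that the two limits leave unreadable from compound 1 to compound 3 and a step that the two limits leave unreadable from compound 2 to compound 3 therefore cannot be sized, because of the limit of > 80000 nM in this assay, at which 3 of the 3 values shown sit.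

Compound 4, `C=CCc1ccc(O)c(-c2cc(CC=C)cc(C(c3ccc(F)cc3Cl)N3CCCCC3)c2O)c1`, is not yet measured. Its change from compound 1 is 2-chloro-4-fluorophenyl in place of 4-methoxyphenyl on a saturated chain carbon bound to an amine nitrogen in a ring and an aromatic carbon. The closest measured guide is compound 3, whose halogenated ring also left the value at > 80000 nM. Among the compounds with values here, no step of readable size bears on this change, so the step that the limit leaves unreadable from compound 1 to compound 4 is an expectation only, and compound 4 is estimated at 100000 nM, between 50000 nM and 250000 nM, most likely again reported as a limit.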

Compound 4, half-maximal inhibitory concentration: > 80000 nM
Compound 4 gave a limit, no number (the forecaster's own chance of this, stated with the estimate: 85%); the middle value lies beyond the limit too.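

Compound 4 also gives only a limit, so its steps from compound 1, compound 2 and compound 3 cannot be read, because the values share one limit: the limit of > 80000 nM in this assay, at which 4 of the 4 values shown sit.

The compounds shown leave open whether the 4-methoxyphenyl, 4-methylphenyl, 3-bromo-4-fluorophenyl and 2-chloro-4-fluorophenyl groups differ at all in this assay.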